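Series notes: decyl replaces hydroxyphenyl on compound 4

This account rests on a few compounds, and the source may have more. Where it says the series, first, only, none or still open, it means among the compounds named here.

Among the measured compounds shown here, compound 2 `O=C1O[C@H]([C@@H](O)Cn2cc(-c3cccc(O)c3)nn2)C(OCc2ccccc2)=C1OCc1ccccc1` is the only member with a numbered result: in a functional assay on HCT-116 cells (Homo sapiens) for antiproliferative activity, read by MTT assay, with a stated time of 72 h (a higher number here means a weaker inhibitor, a lower number a stronger inhibitor), compound 2 gives 42900 nM. Compound 1 `O=C1O/C(=C\Cn2cc(-c3ccc(Br)cc3)nn2)C(OCc2ccccc2)=C1OCc1ccccc1` reaches only a limit in this assay, > 100000 nM. Compound 3 `O=C1O/C(=C\Cn2cc(-c3cc(C(F)(F)F)cc(C(F)(F)F)c3)nn2)C(OCc2ccccc2)=C1OCc1ccccc1` likewise stops at a limit in this assay, > 100000 nM. Two of the three values therefore sit at the limit of > 100000 nM in this assay, at which 2 of the 3 values shown sit, and compound 2 stands alone as the compound with a measured number. Compound 4 `CCCCCCCCCCc1cn(C[C@H](O)[C@H]2OC(=O)C(OCc3ccccc3)=C2OCc2ccccc2)nn1` differs from compound 2 by decyl in place of 3-hydroxyphenyl on an aromatic carbon. For the measured compounds named here, no measured pair differing in one place exists, so the step has no precedent here. A modest step toward a stronger inhibitor is expected, a 2.1-fold lower number from compound 2 to compound 4 (0.33 log units; beyond the scatter). Compound 4 is estimated at 20000 nM in this assay, between 5000 nM and 80000 nM.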

Compound 4, half-maximal inhibitory concentration: 28800 nM
Beside the measured number, compound 4's estimate is 1.4-fold (0.16 log units) below it; measured number inside the range.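

In this assay decyl in place of 3-hydroxyphenyl, on an aromatic carbon of the five-membered aromatic ring with 3 nitrogen, gives a 1.5-fold lower number from compound 2 to compound 4 (0.17 log units; within the scatter) and leaves the two compounds indistinguishable. Among the compounds shown here, this is the only step that can be read at one place. At this position, a chain with no ring and 0 hydrogen-bond donors reads the same as a six-membered aromatic ring carrying a hydroxyl.

From the compounds shown here alone, whether a shorter chain, or an amine or carboxylic acid at the end of the decyl chain, would separate from these two remains open. No measured property shown here bears on this result.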